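This account rests on a few compounds, and the source may have more. Where it says the series, first, only, none or still open, it means among the compounds named here.

Measured compounds:
compound 1 `C=CCSS[C@H]1C[C@H](n2cc(C)c(=O)[nH]c2=O)O[C@@H]1CO` — 34000 nM
compound 2 `CCCCSS[C@H]1C[C@H](n2cc(C)c(=O)[nH]c2=O)O[C@@H]1CO` — 28000 nM
compound 3 `CCCCCCSS[C@H]1C[C@H](n2cc(C)c(=O)[nH]c2=O)O[C@@H]1CO` — 27000 nM

All three share one core and differ only in the chain attached to the outer sulfur of the disulfide. In a functional assay on MOLT-4 cells (Homo sapiens) for cytotoxicity (a higher number here means a weaker inhibitor, a lower number a stronger inhibitor), compound 1 gives the highest of the three numbers, but the steps of a 1.2-fold lower number from compound 1 to compound 2 (0.08 log units; within the scatter) and a 1.3-fold lower number from compound 1 to compound 3 (0.10 log units; within the scatter) are both within the usual scatter, as is a 1.0-fold lower number from compound 2 to compound 3 (0.02 log units; within the scatter), so the three compounds cannot be told apart on these data.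

Compound 4 `Cc1cn([C@H]2C[C@H](SSCCN)[C@@H](CO)O2)c(=O)[nH]c1=O` has not yet been measured. It differs from compound 1 in one place: aminomethyl in place of vinyl on a saturated chain carbon bound to a sulfur. The measured steps bear on this change only in part: they replaced the vinyl with longer saturated chains at the same carbon and none moved the number beyond the scatter, but none of them brought in a hydrogen-bond donor or acceptor, which is what enters here. For the measured compounds named here, with no measured step on a polar group at this position, the step of a 1.1-fold lower number from compound 1 to compound 4 (0.03 log units; within the scatter) is expected to stay small, with a wider range than usual. Compound 4 is therefore estimated at 32000 nM, between 10000 nM and 100000 nM.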

Compound 4, half-maximal inhibitory concentration: 163000 nM
Estimate against measurement, compound 4: 5.1-fold (0.71 log units) below, and the stated range ends below it.
By their numbers in this assay, from the lowest: compounds 3, 2 and 1 (each within the scatter of the next); then compound 4.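

The chain on the outer sulfur is not indifferent after all. Where the allyl, butyl and hexyl chains could not be told apart, the 2-aminoethyl chain in this assay gives a 4.8-fold higher number from compound 1 to compound 4 (0.68 log units; beyond the scatter) and also a 5.8-fold higher number from compound 2 to compound 4 (0.77 log units; beyond the scatter) and a 6.0-fold higher number from compound 3 to compound 4 (0.78 log units; beyond the scatter) in steps beyond the scatter. So in this small set, chain length alone changed nothing that could be read, while the one chain ending in an amino group, the only one with a hydrogen-bond donor and acceptor, makes compound 4 the weakest of the four.

Would a 2-hydroxyethyl chain, a carboxylic acid, or an amine at the end of a longer chain raise the number in the same way? These compounds leave that open, and the data shown offer no explanation for the rise.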